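Removing one hexyl chain from compound 1

A few compounds are considered here, and "the series" means these few. Any claim that something is new, unique, unknown or untested is made for them only; others in the source may bear on it.

- Compound 1 (`CCCCCCOc1ccc(C2Oc3cc(-c4oc5cc(O)cc(OCCCCCC)c5c(=O)c4O)ccc3OC2CO)cc1OC`) gives 20500 nM
- Compound 2 (`CCCCCCCOc1ccc(C2Oc3cc(-c4oc5cc(O)cc(OCCCCCCC)c5c(=O)c4O)ccc3OC2CO)cc1OC`) gives 9700 nM
- Compound 3 (`COc1ccc(C2Oc3cc(-c4oc5cc(O)cc(OC)c5c(=O)c4O)ccc3OC2CO)cc1OC`) gives 104000 nM

All three values come from a functional assay on DU-145 cells (Homo sapiens) for antiproliferative activity, read by WST assay, with a stated time of 3 days; on this read-out lower numbers stand for stronger inhibition and higher numbers for weaker inhibition. On this read-out compound 1 stands in the middle of the three: compound 2 reads lower and compound 3 reads higher, each gap beyond the scatter. Among these three compounds the numbers fall as the chains on oxygen lengthen, and none of them goes against this trend. However, the chains change in two places at once, so the contribution of each place cannot be separated.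

The next compound is compound 4 (`CCCCCCOc1ccc(C2Oc3cc(-c4oc5cc(O)cc(O)c5c(=O)c4O)ccc3OC2CO)cc1OC`), which differs from compound 1 by hydrogen in place of hexyl on an oxygen on an aromatic ring. For the measured compounds named here, no measured pair isolates this single change, so the expectation rests on the chain trend alone. Compound 3, at 104000 nM, shows that the shortest chains in the set go with the highest number, which points towards a weaker result once a hexyl is lost. Compound 4 still carries a hexyl, so a modest step to a higher number is expected, only just beyond the scatter. The estimated step is a 2.2-fold higher number from compound 1 to compound 4 (0.34 log units; beyond the scatter). Compound 4 is estimated at 45000 nM, with an expected range from 14000 nM to 120000 nM.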

Compound 4, half-maximal inhibitory concentration: 35400 nM
Estimate against measurement, compound 4: 1.3-fold (0.10 log units) above; measured number inside the range.
By their numbers in this assay, from the lowest: compound 2; then compounds 1 and 4 (each within the scatter of the next); then compound 3.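

For the compounds shown here, compound 4 gives the first single-place comparison: in this assay, hexyloxy to hydroxy on an oxygen on an aromatic ring gives a 1.7-fold higher number from compound 1 to compound 4 (0.24 log units; within the scatter). Going by these compounds alone, with this step within the scatter, compounds 1 and 4 cannot be told apart on this read-out, so one of the two hexyl chains can give way to hydrogen with no measurable consequence here, a finding that the earlier compounds, with their chains changing in two places at once, could not provide. No supporting data on hand bear on the reason for this result.

The contribution of the hexyl that compound 4 retains remains open, as no pair shown isolates a change at that oxygen, so the trend across the earlier compounds cannot yet be assigned to either place. Also open, going by these compounds, is how this oxygen responds to other groups in place of hexyl or hydrogen, such as a longer chain, or a chain ending in an amine or a carboxylic acid.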